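The source may report more compounds than this note shows. Statements on the series, on what has been measured and on what is new or still open speak of the compounds shown alone.

Compound 1 `CCN(CCCCCCOc1ccc(C(=O)/C=C/c2ccc(N(C)C)cc2)c(O)c1)Cc1ccccc1` was tested in an assay on isolated protein for inhibition of Amine oxidase [flavin-containing] A (Homo sapiens) (on this read-out lower numbers stand for stronger inhibition and higher numbers for weaker inhibition), where compound 1 gives 31600 nM. Among the three compounds measured it stands second highest. Compound 3 `CCN(CCCCOc1ccc(C(=O)/C=C/c2ccc(N(C)C)cc2)c(O)c1)Cc1ccccc1OC` gives 27500 nM, a difference within the scatter. Compound 2 `CCN(CCCCOc1ccc(C(=O)/C=C/c2ccc(N(C)C)cc2)c(O)c1)Cc1ccccc1` gives 77300 nM. The step of a 2.4-fold higher number from compound 1 to compound 2 (0.39 log units; beyond the scatter) lies beyond the scatter. Compound 4 `CCN(CCCCCCOc1ccc(C(=O)/C=C/c2ccc(N(C)C)cc2)c(O)c1)Cc1ccc(N(C)C)cc1` differs from compound 1 by dimethylamino in place of hydrogen on an aromatic carbon on the benzyl ring. Among the compounds with values here, the only measured step that alters this ring is a 2.8-fold lower number from compound 2 to compound 3 (0.45 log units; beyond the scatter), a modest gain. Compound 4 is therefore expected to show a 1.8-fold lower number from compound 1 to compound 4 (0.24 log units; within the scatter), a small lowering, though a step within the scatter cannot be excluded. Compound 4 is estimated at 18000 nM, with a range from 6000 nM to 50000 nM.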

Compound 4, half-maximal inhibitory concentration: 53600 nM
Beside the measured number, compound 4's estimate is 3.0-fold (0.47 log units) below it, outside the stated range (above it).
By their numbers in this assay, from the lowest: compounds 3, 1, 4 and 2 (each within the scatter of the next, the first and the last beyond it).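

Placing dimethylamino on the aromatic carbon para to a large group of the benzyl ring of compound 1 gives, in this assay, a 1.7-fold higher number from compound 1 to compound 4 (0.23 log units; within the scatter), so this substitution leaves the read-out within the scatter. Within the data shown here, the only earlier change on this ring, methoxy in compound 3, gave a 2.8-fold lower number from compound 2 to compound 3 (0.45 log units; beyond the scatter), so a substituent on this ring does not always move the number beyond the scatter. Nothing available explains this result. On these data alone, it remains open whether methoxy on the benzyl ring of compound 1, or a carboxylic acid at the dimethylamino position, would give a step beyond the scatter.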